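The source may report more compounds than this note shows. Statements on the series, on what has been measured and on what is new or still open speak of the compounds shown alone.

Compound 2 `O=C(O)c1ccccc1-c1ccc(CCc2ncc(CC3CCOCC3)[nH]2)cc1` stands at the low end of the three numbers measured in an in vitro functional assay on cells for agonist activity at Bombesin receptor subtype-3 (Homo sapiens), read by luminescence and calcium flux (a higher number here means that more compound is needed for the effect, a lower number that less compound is needed), where compound 2 gives 338 nM. Compound 1 `O=C(O)c1ccccc1-c1ccc(CCc2ncc(CC3CCC3)[nH]2)cc1` gives 588 nM in this assay, and the step of a 1.7-fold lower number from compound 1 to compound 2 (0.24 log units; within the scatter) does not separate the two. Compound 3 `COc1ccc(Cc2cnc(CCc3ccc(-c4ccccc4C(=O)O)cc3)[nH]2)cc1` gives 5360 nM, a clearly weaker result, reached by the step of a 16-fold higher number from compound 2 to compound 3 (1.20 log units; beyond the scatter) and, from the other saturated ring, by the step of a 9.1-fold higher number from compound 1 to compound 3 (0.96 log units; beyond the scatter). Compound 4 `O=C(O)c1ccccc1-c1ccc(CCc2ncc(Cc3cccc(F)c3F)[nH]2)cc1` differs from compound 2 in one place: 2,3-difluorophenyl in place of oxan-4-yl on a saturated chain carbon bound to an aromatic carbon. Both measured steps that bear on this change replace a saturated ring by an aromatic one, and both raise the number beyond the scatter; compound 4 carries a different aromatic ring, bearing fluorine rather than a methoxy group, so the size of the step is uncertain. A rise is therefore expected, and compound 4 is estimated at 2000 nM, with a range from 600 nM to 7000 nM. The change expected is a 5.9-fold higher number from compound 2 to compound 4 (0.77 log units; beyond the scatter).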

Compound 4, half-maximal effective concentration: 87 nM
Compound 4: the middle estimate sits 23-fold (1.36 log units) above what was measured; the whole stated range lies above it.
By their numbers in this assay, from the lowest: compound 4; then compounds 2 and 1 (each within the scatter of the next); then compound 3.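

In this assay, an aromatic ring at this position does not by itself raise the number: 2,3-difluorophenyl gives a 3.9-fold lower number from compound 2 to compound 4 (0.59 log units; beyond the scatter) and a 6.8-fold lower number from compound 1 to compound 4 (0.83 log units; beyond the scatter), whereas 4-methoxyphenyl in compound 3 goes the other way against the same saturated rings. What the aromatic ring carries therefore matters greatly on this saturated chain carbon, as the change between the two aromatic groups gives a 62-fold lower number from compound 3 to compound 4 (1.79 log units; beyond the scatter). Nothing available offers a measured explanation for this reversal.

Going by these compounds, it remains open whether both fluorines are needed, and where a plain phenyl, a 3-fluorophenyl or a 2-fluorophenyl group would stand. Also open, on these data alone, is how a pyridyl ring or a chlorine-bearing phenyl ring would compare with 2,3-difluorophenyl at this position.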